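Cytotoxicity series: bromophenyl to nitrophenyl swap repeated

The source may hold more compounds than are shown below. What is called first, only, known or untested is meant among the compounds shown, and "the series" means these compounds.

Measured so far:
compound 1 `COc1cc2c(Oc3ccc(NC(=O)c4nn(-c5ccccc5Br)c(=O)c5ccccc45)cc3F)ccnc2cc1OCCCN1CCCC1` 410 nM
compound 2 `COc1cc2c(Oc3ccc(NC(=O)c4nn(-c5ccc([N+](=O)[O-])cc5)c(=O)c5ccccc45)cc3F)ccnc2cc1OCCCN1CCCC1` 1620 nM
compound 3 `COc1cc2c(Oc3ccc(NC(=O)c4nn(-c5ccccc5Br)c(=O)c5ccccc45)cc3F)ccnc2cc1OCCCN1CCC(C)CC1` 510 nM

All three were read in a functional assay on MKN-45 cells (Homo sapiens) for cytotoxicity, read by MTT assay, with a stated time of 72 h; a lower number here means a stronger inhibitor, a higher number a weaker inhibitor. Compound 1 gives 410 nM and compound 3 gives 510 nM; the two differ only in the amine at the end of the propoxy chain, (4-methylpiperidin-1-yl in place of pyrrolidin-1-yl on a saturated chain carbon, three bonds along the chain from an oxygen on an aromatic ring), and the step of a 1.2-fold higher number from compound 1 to compound 3 (0.09 log units; within the scatter) is within the scatter, so the two cannot be ordered. Compound 2 gives 1620 nM; against compound 1 it carries 4-nitrophenyl in place of 2-bromophenyl on an aromatic nitrogen, and that change costs a 4.0-fold higher number from compound 1 to compound 2 (0.60 log units; beyond the scatter), a step beyond the scatter.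

Compound 4 `COc1cc2c(Oc3ccc(NC(=O)c4nn(-c5ccc([N+](=O)[O-])cc5)c(=O)c5ccccc45)cc3F)ccnc2cc1OCCCN1CCC(C)CC1` is not yet measured. It differs from compound 3 by 4-nitrophenyl in place of 2-bromophenyl on an aromatic nitrogen. Among the compounds with values here, this is the same change as the one from compound 1 to compound 2, and the surroundings of the place are described in identical words in both cases, so the two are taken as the same change on two cores that differ only by 4-methylpiperidin-1-yl in place of pyrrolidin-1-yl on a saturated chain carbon, three bonds along the chain from an oxygen on an aromatic ring. Within the data shown here, only one instance of this change has been measured, so the expectation rests on a single step.

Among the measured compounds shown here, for compound 4 in this assay the expected step is a 3.9-fold higher number from compound 3 to compound 4 (0.59 log units; beyond the scatter), matching the earlier one, because a 4.0-fold higher number from compound 1 to compound 2 (0.60 log units; beyond the scatter) is the only guide available and because a 1.2-fold higher number from compound 1 to compound 3 (0.09 log units; within the scatter) shows the amine swap on its own barely moves the number. Compound 4 is therefore estimated at 2000 nM, with a likely range from 900 nM to 4500 nM.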

Compound 4, half-maximal inhibitory concentration: 1150 nM
For compound 4 the middle estimate is 1.7-fold (0.24 log units) above the measured one; low and high end bracket the measured number.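

In this assay, the change to 4-nitrophenyl in place of 2-bromophenyl again gives a higher number when the chain ends in 4-methylpiperidin-1-yl, with a 2.3-fold higher number from compound 3 to compound 4 (0.35 log units; beyond the scatter), and the two instances of this change cannot be told apart in size: the same change on two cores in this assay, a 4.0-fold higher number (0.60 log units; beyond the scatter) from compound 1 to compound 2 and a 2.3-fold higher number (0.35 log units; beyond the scatter) from compound 3 to compound 4, 1.8-fold (0.24 log units) apart, within the scatter of two such steps

The amine swap stays small with 4-nitrophenyl in place, with a 1.4-fold lower number from compound 2 to compound 4 (0.15 log units; within the scatter), and it also agrees with its earlier instance: the same change on two cores in this assay, a 1.2-fold higher number (0.09 log units; within the scatter) from compound 1 to compound 3 and a 1.4-fold lower number (0.15 log units; within the scatter) from compound 2 to compound 4, 1.8-fold (0.24 log units) apart, within the scatter of two such steps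

Across these four compounds, the aryl change and the amine change can therefore be carried from one core to the other without a detectable shift in step size, but this rests on two instances of each change, in one assay, on cores that differ only in the amine, and it does not show that the step would hold on a more different core or explain why the number rises.

Still open, from the compounds shown here alone, is whether the step follows from the identity of the substituent or from where it sits, which a 4-bromophenyl or 2-nitrophenyl group would help to separate. Also open, going by these compounds, is whether the amine swap stays this small with a morpholine at the end of the chain or with a longer chain.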